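Notes on the terminal-group swap in the sulfone series

A few compounds are considered here, and "the series" means these few. Any claim that something is new, unique, unknown or untested is made for them only; others in the source may bear on it.

Compound 3 `CNCC(=O)NC[C@@H]1CCCc2cc(S(=O)(=O)c3cccc(F)c3)ccc21` stands second highest of three numbers in an assay on isolated protein for displacement of a labelled ligand from 5-hydroxytryptamine receptor 6 (Homo sapiens) (on this read-out lower numbers stand for stronger inhibition and higher numbers for weaker inhibition), giving 0.159 nM. Nearest is compound 2 `O=C1CN=C(NC[C@@H]2CCCc3cc(S(=O)(=O)c4cccc(F)c4)ccc32)N1`, which gives 0.1 nM, a gap of a 1.6-fold higher number from compound 2 to compound 3 (0.20 log units; within the scatter). Furthest is compound 1 `CN(C[C@@H]1CCCc2cc(S(=O)(=O)c3cccc(F)c3)ccc21)S(N)(=O)=O`, which gives 3.98 nM, separated by a 25-fold lower number from compound 1 to compound 3 (1.40 log units; beyond the scatter). Compound 4 `O=C(CO)NC[C@@H]1CCCc2cc(S(=O)(=O)c3cccc(F)c3)ccc21` is unmeasured and differs from compound 3 by hydroxy in place of methylamino on a saturated chain carbon bound to a carbonyl carbon. Within the data shown here, no measured step touches that position alone. The step of a 1.6-fold higher number from compound 2 to compound 3 (0.20 log units; within the scatter) shows two different groups on the amine nitrogen giving numbers within the scatter, while a 40-fold lower number from compound 1 to compound 2 (1.60 log units; beyond the scatter) concerns the change at the chain carbon bound to the saturated ring carbon, which compound 4 keeps. The expected step is a 3.1-fold higher number from compound 3 to compound 4 (0.50 log units; beyond the scatter). Compound 4 is estimated at 0.5 nM in this assay, between 0.15 nM and 2 nM.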

Compound 4, inhibition constant: 0.1 nM
The estimate for compound 4 lay 5.0-fold (0.70 log units) above the measured number; the whole stated range lies above it.
By their numbers in this assay, from the lowest: compounds 2, 4 and 3 (each within the scatter of the next); then compound 1.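

At the saturated chain carbon bound to a carbonyl carbon, hydroxy in place of methylamino stays within the scatter in this assay (a 1.6-fold lower number from compound 3 to compound 4 (0.20 log units; within the scatter)), so the methylamino nitrogen is not needed for numbers of this size. The hydroxymethyl group, which has no ring, also matches the ring-bearing group on the amine nitrogen (no change at the digits printed from compound 2 to compound 4 (within the scatter)), and the large gap from the methyl(sulfamoyl)amino group remains (a 40-fold lower number from compound 1 to compound 4 (1.60 log units; beyond the scatter)). No measurement offers an explanation for this result.

Going by these compounds, whether a methoxy group, a carboxylic acid or a longer chain at this place would hold the number remains open.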